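A few compounds are considered here, and "the series" means these few. Any claim that something is new, unique, unknown or untested is made for them only; others in the source may bear on it.

In a functional assay on MCF7 cells (Homo sapiens) for inhibition, read by sulforhodamine B assay (on this read-out lower numbers stand for stronger inhibition of growth and higher numbers for weaker inhibition of growth), compound 2 (`COc1cc(-c2ccc(-c3ccc(-c4nc5cc(C)ccc5[nH]4)cc3)cc2)cc(OC)c1OC`) gives 170 nM, level with compound 1 (`COc1ccc(-c2ccc(-c3ccc(-c4nc5cc(C)ccc5[nH]4)cc3)cc2)cc1OC`) at 190 nM. Adding one methoxy gives a 1.1-fold lower number from compound 1 to compound 2 (0.05 log units; within the scatter). Compound 3 (`Oc1cccc2[nH]c(-c3ccc(-c4ccc(-c5ccccc5)cc4)cc3)nc12`) gives 2200 nM, clearly weaker inhibition of growth than both; it carries the 4-hydroxy-1H-benzimidazol-2-yl group but no methoxy. Compound 4 (`COc1cc(-c2ccc(-c3ccc(-c4nc5c(O)cccc5[nH]4)cc3)cc2)cc(OC)c1OC`) keeps the methoxy groups of compound 2 and makes one change: 4-hydroxy-1H-benzimidazol-2-yl in place of 5-methyl-1H-benzimidazol-2-yl on an aromatic carbon. Among the compounds with values here, no measured step isolates this swap. Within the data shown here, the only hint is compound 3 at 2200 nM, which also differs from compound 2 elsewhere, so only part of that gap is expected to carry over. A move towards a higher number is expected, namely a 2.9-fold higher number from compound 2 to compound 4 (0.47 log units; beyond the scatter). Compound 4 is estimated at 500 nM, with an expected range of 130 nM to 2200 nM.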

Compound 4, concentration for 50% growth inhibition: < 100 nM
Compound 4: only a limit was reported; the forecaster's own chance of this, stated with the estimate: 3%; at least 5.0-fold (0.69 log units) between middle value and limit.
By their numbers in this assay, from the lowest: compounds 2 and 1 (each within the scatter of the next); then compound 3. At a limit, below all of these: compound 4.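

In this assay, replacing 5-methyl-1H-benzimidazol-2-yl with 4-hydroxy-1H-benzimidazol-2-yl on the core of compound 2 costs no growth inhibition, giving an at least 1.7-fold lower number from compound 2 to compound 4 (0.23 log units; that floor lies within the scatter). The weak reading of compound 3 therefore does not come from the 4-hydroxy-1H-benzimidazol-2-yl group alone. The reading for compound 4 is a limit, not a number, so any true gain over compound 2 remains unproven: the limit of < 100 nM in this assay, at which 1 of the 4 values shown sits.

The compounds shown do not separate gaining the hydroxyl from losing the methyl. From the compounds shown here alone, how an amine or a carboxylic acid would read in the hydroxyl's place also remains open.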